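The source may report more compounds than this note shows. Statements on the series, on what has been measured and on what is new or still open speak of the compounds shown alone.

Compound 3 `C[C@H](Nc1ncnc2[nH]cnc12)c1nn(-c2cccnc2)c2cc(F)ccc12` is the only one of the three measured compounds that gives a number in a functional assay on Hep 3B2 cells (Homo sapiens) for inhibition, read by sulforhodamine B assay, with a stated time of 72 h; a higher number here means a weaker inhibitor, a lower number a stronger inhibitor: compound 3 shows 34500 nM. Compound 1 `C[C@H](Nc1ncnc2[nH]cnc12)c1nn(-c2cccnc2)c2cc(Cl)ccc12` reaches only a limit of the assay there, > 40000 nM. Compound 2 `C[C@H](Nc1nc(N)nc2[nH]cnc12)c1nn(-c2cccnc2)c2cc(F)ccc12` likewise reaches only a limit, > 40000 nM. The steps of an at least 1.1-fold lower number from compound 1 to compound 3 (0.06 log units; that floor lies within the scatter) and an at least 1.1-fold lower number from compound 2 to compound 3 (0.06 log units; that floor lies within the scatter) are therefore floors rather than measured sizes, since both rest on (the limit of > 40000 nM in this assay, at which 2 of the 3 values shown sit). Compound 4 `C[C@H](Nc1ncnc2[nH]cnc12)c1nn(-c2cccc(S(C)(=O)=O)c2)c2cc(F)ccc12` differs from compound 3 at a different place altogether: 3-(methylsulfonyl)phenyl in place of pyridin-3-yl on an aromatic nitrogen. Among the compounds with values here, no measured step touches this position, so no change beyond the scatter is expected for the step of a 1.2-fold lower number from compound 3 to compound 4 (0.06 log units; within the scatter). Compound 4 is accordingly estimated at 30000 nM, within a range from 8000 nM to 40000 nM, with a real chance that the assay again reports only a limit.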

Compound 4, half-maximal inhibitory concentration: 13000 nM
For compound 4 the middle estimate is 2.3-fold (0.36 log units) above the measured one, within the range that was stated.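

With 3-(methylsulfonyl)phenyl in place of pyridin-3-yl on the aromatic nitrogen, this assay gives a 2.7-fold lower number from compound 3 to compound 4 (0.42 log units; beyond the scatter). This shows that a change at this position can shift the number by more than the usual scatter. The earlier steps, at other places, gave only floors: the limit of > 40000 nM in this assay, at which 2 of the 4 values shown sit.

As far as these compounds go, whether the step comes from the methylsulfonyl group or from the carbon-only ring stays open, as does what a plain phenyl or a phenyl bearing a carboxylic acid would give here. It is also unknown whether the same change would lower the number with chloro on the core, or with the added amino group.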